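The source may report more compounds than this note shows. Statements on the series, on what has been measured and on what is new or still open speak of the compounds shown alone.

Compound 1 `CCOC(=O)/C=C/c1ccncc1-c1ccc2[nH]ccc2c1` carries an ethyl ester on the chain that hangs from the shared core. In a functional assay on MCF7 cells (Homo sapiens) for inhibition, read by sulforhodamine B assay, with a stated time of 72 h (a higher number here means a weaker inhibitor of growth, a lower number a stronger inhibitor of growth), compound 1 gives only a limit of the assay, > 10000 nM, and not a number. Two related compounds have been run in the same test. Compound 2 `O=C(O)CCc1ccncc1-c1ccc2ccccc2c1` has a carboxylic acid on a saturated chain and a different second ring; in this assay compound 2 also gives a limit, > 10000 nM. Compound 3 `NNC(=O)CCc1ccncc1-c1ccc2ccccc2c1` has aminoamino in place of hydroxy on a carbonyl carbon; in this assay compound 3 again gives a limit, > 10000 nM. The step from compound 2 to compound 3 therefore cannot be sized: a step that the two limits leave unreadable from compound 2 to compound 3. For the measured compounds named here, every value so far sits at the same edge, (the limit of > 10000 nM in this assay, at which 3 of the 3 values shown sit), so compound 1 stands at the boundary of what the test can see, no better placed than the others.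

Compound 4 `O=C(O)/C=C/c1ccncc1-c1ccc2[nH]ccc2c1` has not been measured. It differs from compound 1 in one place: hydrogen in place of ethyl on an oxygen next to a carbonyl group. Going by the values given here, no measured step mirrors this change, and the single step between compounds sharing a carbonyl is unreadable. With nothing pointing toward stronger inhibition, the expectation in this assay is for no step beyond the scatter, and most likely another limit. Compound 4 is therefore expected to give about 20000 nM, in a range from 8000 nM to 100000 nM. The estimated step from compound 1 to compound 4 is a step that the limit leaves unreadable from compound 1 to compound 4.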

Compound 4, concentration for 50% growth inhibition: > 10000 nM
Compound 4: only a limit was reported; the forecaster's own chance of this, stated with the estimate: 85%; the middle value lies beyond the limit too.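

In this assay compound 4 gives > 10000 nM, a limit and not a number. For the compounds shown here, compound 1 also gives only a limit, so no step from compound 1 to compound 4 can be read. All the compounds shown sit at one edge: the limit of > 10000 nM in this assay, at which 4 of the 4 values shown sit. They leave open what size of effect hydrogen in place of ethyl has, and which change to the shared core would give a readable value.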